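The source may hold more compounds than are shown below. What is called first, only, known or untested is meant among the compounds shown, and "the series" means these compounds.

Series notes. Of the compounds shown here, three with the shared core have numbers so far. Compound 1 `O=S(=O)(CSc1nnc(Br)n1Cc1ccc(Br)c2ccccc12)Nc1cccnc1` gives 32 nM in an assay on HEK293 cells for inhibition of solute carrier family 22 member 12 (Homo sapiens); on this read-out lower numbers stand for stronger inhibition and higher numbers for weaker inhibition. Compound 2 `O=S(=O)(CSc1nnc(Br)n1Cc1ccc(Br)c2ccccc12)Nc1cncc(C(F)(F)F)c1` gives 6380 nM in this assay, and compound 3 `O=S(=O)(CSc1nnc(Br)n1Cc1ccc(Br)c2ccccc12)Nc1ccc(Cl)nc1` gives 1940 nM in this assay, the second highest of the three numbers: its nearest neighbour is compound 2, separated by a 3.3-fold lower number from compound 2 to compound 3 (0.52 log units; beyond the scatter), and its furthest is compound 1, separated by a 61-fold higher number from compound 1 to compound 3 (1.78 log units; beyond the scatter).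

Compound 4 `O=S(=O)(CSc1nnc(Br)n1Cc1ccc(Br)c2ccccc12)Nc1cc(Cl)cnc1Cl` is not yet measured. The change from compound 3 is 2,5-dichloropyridin-3-yl in place of 6-chloropyridin-3-yl on a sulfonamide nitrogen. Going by the values given here, the steps that bear on it are the two in which a group was added on an aromatic carbon of the ring attached to the sulfonamide nitrogen: a 61-fold higher number from compound 1 to compound 3 (1.78 log units; beyond the scatter) and a 200-fold higher number from compound 1 to compound 2 (2.30 log units; beyond the scatter), both large and both towards higher numbers. A second chloro is another such addition, so for compound 4 a further rise in this assay is expected, likely smaller than those two, a step of about a 2.6-fold higher number from compound 3 to compound 4 (0.41 log units; beyond the scatter). Compound 4 is therefore estimated at 5000 nM, with a range from 1200 nM to 20000 nM.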

Compound 4, half-maximal inhibitory concentration: 2790 nM
Estimate against measurement, compound 4: 1.8-fold (0.25 log units) above, and the stated range covers the measured number.
By their numbers in this assay, from the lowest: compound 1; then compounds 3 and 4 (each within the scatter of the next); then compound 2.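

In this assay, 2,5-dichloropyridin-3-yl and 6-chloropyridin-3-yl cannot be told apart (a 1.4-fold higher number from compound 3 to compound 4 (0.16 log units; within the scatter)), so the larger group with its second chloro brings no further rise beyond the single-chloro ring. All of the substituted rings shown remain far from the unsubstituted pyridin-3-yl (an 87-fold higher number from compound 1 to compound 4 (1.94 log units; beyond the scatter)), while the dichloro group still gives a lower number than the 5-(trifluoromethyl)pyridin-3-yl group (a 2.3-fold lower number from compound 2 to compound 4 (0.36 log units; beyond the scatter)); among these four compounds, none goes against the rise on substitution. No measured information is available to explain these differences.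

Still open, going by these compounds, is whether a single fluoro, a methyl or an amine on the pyridin-3-yl ring would stay close to compound 1 (32 nM). The compounds shown also do not separate the contribution of each chloro within the 2,5-dichloropyridin-3-yl group.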